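Swapping a Para Methyl for Chloro on the Amide

The source may hold more compounds than are shown below. What is called first, only, known or untested is meant among the compounds shown, and "the series" means these compounds.

Of the compounds shown here, two built on one shared core have been measured in a functional assay on MDA-MB-231 cells (Homo sapiens) for antiproliferative activity, read by CCK-8 assay, with a stated time of 72 h; a higher number here means a weaker inhibitor, a lower number a stronger inhibitor. Compound 1 `O=C(Nc1cccc(-c2oc3cc(-c4ccc(F)cc4)ccc3c(=O)c2O)c1)c1ccccc1F` gives 7240 nM. Compound 2 `Cc1ccc(C(=O)Nc2cccc(-c3oc4cc(-c5ccc(F)cc5)ccc4c(=O)c3O)c2)cc1` gives 4350 nM; on the numbers shown it sits at the low end, but the only step that joins it to another compound, a 1.7-fold lower number from compound 1 to compound 2 (0.22 log units; within the scatter), exchanges the whole ring on the carbonyl carbon and stays within the scatter. Compound 3 `O=C(Nc1cccc(-c2oc3cc(-c4ccc(F)cc4)ccc3c(=O)c2O)c1)c1ccc(Cl)cc1` is not yet measured. It differs from compound 2 in one place: chloro in place of methyl on an aromatic carbon. Among the measured compounds shown here, the only measured step that bears on this change is the one from compound 1 to compound 2, which also alters the ring on the carbonyl carbon and produced no shift beyond the scatter. That single step gives little ground to expect this assay to move beyond the scatter in either direction when chloro replaces methyl. Compound 3 is therefore estimated to give about 4000 nM, within a range from 1500 nM to 11000 nM. The expected step of a 1.1-fold lower number from compound 2 to compound 3 (0.04 log units; within the scatter) amounts to no change beyond the scatter.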

Compound 3, half-maximal inhibitory concentration: 12800 nM
For compound 3 the middle estimate is 3.2-fold (0.51 log units) below the measured one, and the stated range ends below it.
By their numbers in this assay, from the lowest: compounds 2, 1 and 3 (each within the scatter of the next, the first and the last beyond it).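

In this assay, exchanging a single heavy atom on the aromatic carbon para to a large group gives a 2.9-fold higher number from compound 2 to compound 3 (0.47 log units; beyond the scatter), a modest step but the only one in this small set that lies beyond the scatter. It shows that this position does not treat 4-methylphenyl and 4-chlorophenyl alike, even though the counts of rings, hydrogen-bond donors, hydrogen-bond acceptors and net charge stay the same, while the whole-ring exchange from 2-fluorophenyl to 4-chlorophenyl gives a 1.8-fold higher number from compound 1 to compound 3 (0.25 log units; within the scatter) and stays within the scatter. Nothing available accounts for the difference between methyl and chloro here, so the step stands as an observation without an explanation.

With only methyl and chloro at this position, two points cannot show whether the trend depends on the group's identity in any general way, and a hydrogen, a methoxy group, an amine or a carboxylic acid on the same carbon would test that directly. As far as these compounds go, it also remains open whether the same exchange of methyl for chloro would give a similar step on a ring carrying a different substitution pattern, or on a different core.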